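The compounds below may be only part of what the source reports. "The series", "measured", "known", "first", "only" and "open" are said of these compounds alone.

Compound 1 `Cc1ccc2c(c1)N(S(=O)(=O)c1ccc(-c3cnc(C4CC4)o3)cc1)CCCO2`: 41 nM
Compound 2 `O=S(=O)(c1ccc(-c2cnc(C3CC3)o2)cc1)N1CCCOc2ccccc21`: 27 nM

Both numbers come from a functional assay on PC-3 cells (Homo sapiens) for antiproliferative activity, read by MTT assay, with a stated time of 72 h; a higher number here means a weaker inhibitor, a lower number a stronger inhibitor. Only these two compounds have been measured, and compound 1 cannot be told apart from the other: the step is a 1.5-fold lower number from compound 1 to compound 2 (0.18 log units; within the scatter). Compound 3 `O=S(=O)(c1ccc(-c2cnc(C3CC3)o2)cc1)N1CCCOc2ccc(Cl)cc21` keeps the core of compound 1 but has chloro in place of methyl on an aromatic carbon. Among the compounds with values here, the one measured step that bears on this is the removal of that same methyl, a 1.5-fold lower number from compound 1 to compound 2 (0.18 log units; within the scatter). Within the data shown here, it shows that the number changes little when the methyl goes, but no chloro compound has been measured yet, so this is only a loose guide. In this assay, no change beyond the scatter is therefore expected, and the estimate is a 1.2-fold lower number from compound 1 to compound 3 (0.07 log units; within the scatter). For compound 3 the expected value is 35 nM, with an estimated range from 15 nM to 85 nM.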

Compound 3, half-maximal inhibitory concentration: 18 nM
For compound 3 the middle estimate is 1.9-fold (0.29 log units) above the measured one, and the stated range covers the measured number.
By their numbers in this assay, from the lowest: compounds 3, 2 and 1 (each within the scatter of the next, the first and the last beyond it).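

In this assay this position now gives its first step beyond the scatter: chloro in place of methyl on an aromatic carbon separates the two compounds, though only modestly (a 2.3-fold lower number from compound 1 to compound 3 (0.36 log units; beyond the scatter)). Chloro in place of hydrogen stays within the scatter (a 1.5-fold lower number from compound 2 to compound 3 (0.18 log units; within the scatter)), so compound 2, with hydrogen, cannot be told apart from either compound 1 or compound 3, and only the two substituted compounds can be ranked against each other. Nothing at hand explains why chloro and methyl differ at this position.

The compounds shown leave open how an amine, a methoxy group or a longer chain would read at this position. They also leave open whether chloro in place of methyl would give a similar step on a different core.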